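The source may report more compounds than this note shows. Statements on the series, on what has been measured and on what is new or still open speak of the compounds shown alone.

Working notes on the series, all read in a functional assay on MCF7 cells (Homo sapiens) for inhibition, with a stated time of 48 h; on this read-out higher numbers stand for weaker inhibition and lower numbers for stronger inhibition. Of the compounds shown here, three have numbers so far. Compound 1 (`Cc1cc(C)cc(Sc2c[nH]c3ccc(Cl)cc23)c1`) gives 1200 nM, compound 2 (`COc1cc(Sc2c(C)[nH]c3ccc(Cl)cc23)cc(OC)c1OC`) gives 82 nM, and compound 3 (`COc1cc(Sc2c[nH]c3ccc([N+](=O)[O-])cc23)cc(OC)c1OC`) gives 560 nM. Compound 3 therefore stands in the middle of the three, with compound 1 at a higher number and compound 2 at a lower one, and both gaps lie beyond the scatter. Among the measured compounds shown here, no two measured compounds differ in one place only, so the series offers no single-change step to size the next one.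

Compound 4 (`COc1cc(Sc2c[nH]c3ccc(OCCOCc4ccccc4)cc23)cc(OC)c1OC`) takes compound 3 as its reference, with 2-(benzyloxy)ethoxy in place of nitro on an aromatic carbon. The entering group is the larger of the two and brings a six-membered aromatic ring of carbon only. For the measured compounds named here, nothing measured so far shows what this exchange does, so no firm direction can be argued from the series. The expected change is a 1.3-fold higher number from compound 3 to compound 4 (0.10 log units; within the scatter), estimated to stay within the scatter, and the wide range allows for movement either way. For compound 4 the estimated value is 700 nM, with an expected range of 150 nM to 3000 nM.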

Compound 4, half-maximal inhibitory concentration: 260 nM
Compound 4: the middle estimate sits 2.7-fold (0.43 log units) above what was measured; the range from low to high includes it.
By their numbers in this assay, from the lowest: compound 2; then compound 4; then compound 3; then compound 1.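

this assay now has its first single-change step: 2-(benzyloxy)ethoxy in place of nitro gives a 2.2-fold lower number from compound 3 to compound 4 (0.33 log units; beyond the scatter), a modest move toward stronger inhibition. Among the compounds shown here, the aromatic carbon that is meta to a fused ring and para to a fused ring therefore accepts a much larger group, with 11 heavy atoms against 3 and an added six-membered aromatic ring of carbon only, and inhibition does not weaken; the earlier compounds gave no view of this. No measurement at hand bears on the cause of this step.

A single step cannot separate the loss of nitro from the gain of the chain and its aromatic ring, so a methoxy group, a 2-hydroxyethoxy chain without the benzyl ring, or an amine on the same aromatic carbon would be needed to tell these contributions apart. On these data alone, it also remains open whether the gain grows, shrinks or reverses with a longer chain between the oxygen atoms, or on the methyl-bearing core of compound 2.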